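A few compounds are considered here, and "the series" means these few. Any claim that something is new, unique, unknown or untested is made for them only; others in the source may bear on it.

Compound 1 `Nc1ccccc1/C=C/c1ccccc1O`: 39 ug/mL
Compound 2 `COc1ccccc1/C=C/c1ccccc1O`: 17.9 ug/mL
Compound 3 `Nc1cccc(/C=C/c2cccc(O)c2)c1`: 54 ug/mL

In a functional assay on MCF7 cells (Homo sapiens) for inhibition, read by MTT assay, with a stated time of 2 days (a lower number here means a stronger inhibitor, a higher number a weaker inhibitor), compound 3 gives the highest number of the three, but its gap to compound 1 lies within the scatter, so no order between those two is claimed. Compound 1 and compound 2 differ in one place (methoxy in place of amino on an aromatic carbon), and the step of a 2.2-fold lower number from compound 1 to compound 2 (0.34 log units; beyond the scatter) is modest yet beyond the scatter. Compound 4 `COc1cccc(/C=C/c2cccc(O)c2)c1` stands to compound 3 as compound 2 stands to compound 1 (methoxy in place of amino on an aromatic carbon). It is the same kind of change, not the same: in compound 1 the group sits ortho to a group of 9 heavy atoms, in compound 3 meta to a group of 9 heavy atoms. How the cores of compound 1 and compound 3 differ is not broken down here. Resting on a 2.2-fold lower number from compound 1 to compound 2 (0.34 log units; beyond the scatter), compound 4 is expected to show a step of a 2.2-fold lower number from compound 3 to compound 4 (0.33 log units; beyond the scatter) in this assay. Compound 4 is therefore estimated at 25 ug/mL, between 12 ug/mL and 50 ug/mL.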

Compound 4, half-maximal inhibitory concentration: 13 ug/mL
Estimate against measurement, compound 4: 1.9-fold (0.28 log units) above; low and high end bracket the measured number.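

In this assay, methoxy in place of amino on an aromatic carbon again gives a lower number, here with a 4.2-fold lower number from compound 3 to compound 4 (0.62 log units; beyond the scatter). Set beside the earlier step, the new one does not differ from it by more than the usual scatter: the same change on two cores in this assay, a 2.2-fold lower number (0.34 log units; beyond the scatter) from compound 1 to compound 2 and a 4.2-fold lower number (0.62 log units; beyond the scatter) from compound 3 to compound 4, 1.9-fold (0.28 log units) apart, within the scatter of two such steps. On these two cores the change therefore carries over in direction and in a comparable size, but two pairs establish no rule for other cores and do not show what produces the step.

The compounds shown leave open whether a carboxylic acid or a nitrile in the same place would give a lower number as methoxy does. They also leave open whether the step holds outside this assay.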